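Notes on a bromo-for-hydrogen change across two cores

The compounds below may be only part of what the source reports. "The series", "measured", "known", "first", "only" and "open" are said of these compounds alone.

Compound 1 `O=C1N=C(N2N=C(c3ccccc3)CC2c2ccccc2O)S/C1=C1/C(=O)Nc2ccccc21` gives 2050 nM in a functional assay on cells (Cancer cell lines, Homo sapiens) for cytotoxicity, read by sulforhodamine B assay, with a stated time of 48 h; on this read-out higher numbers stand for weaker inhibition of growth and lower numbers for stronger inhibition of growth. Compound 2 `O=C1N=C(N2N=C(c3ccccc3)CC2c2ccccc2O)S/C1=C1/C(=O)Nc2ccc(Br)cc21` differs from it only by bromo in place of hydrogen on an aromatic carbon, and in this assay compound 2 gives 290 nM, a step of a 7.1-fold lower number from compound 1 to compound 2 (0.85 log units; beyond the scatter). Compound 3 `COc1ccc(C2=NN(C3=NC(=O)/C(=C4\C(=O)Nc5ccccc54)S3)C(c3ccc(OC)cc3)C2)cc1` rests on a different core; the difference between the two cores is not broken down here. In this assay compound 3 gives 100000 nM, the highest of the three numbers and well beyond the scatter from both compound 1 and compound 2. Compound 4 `COc1ccc(C2=NN(C3=NC(=O)/C(=C4\C(=O)Nc5ccc(Br)cc54)S3)C(c3ccc(OC)cc3)C2)cc1` has not been measured; it differs from compound 3 by bromo in place of hydrogen on an aromatic carbon, the same kind of change as from compound 1 to compound 2, with the place described in the same words. The change has been measured once, on the core of compound 1, so its transfer to the core of compound 3 is uncertain, the more so as the number for compound 3 stands far above the others. A lower number is nevertheless expected for compound 4, estimated as a step of a 3.3-fold lower number from compound 3 to compound 4 (0.52 log units; beyond the scatter), resting on a 7.1-fold lower number from compound 1 to compound 2 (0.85 log units; beyond the scatter) seen before. Compound 4 is therefore estimated at 30000 nM, expected to fall between 6000 nM and 100000 nM.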

Compound 4, concentration for 50% growth inhibition: 270 nM
Compound 4: the middle estimate sits 110-fold (2.05 log units) above what was measured, outside the stated range (below it).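

In this assay, bromo in place of hydrogen on an aromatic carbon gives a 370-fold lower number from compound 3 to compound 4 (2.57 log units; beyond the scatter), a large step in the same direction as on the core of compound 1. The direction therefore carries across the two cores in this series, but the size does not, so a step measured on one core gives no safe figure for the other: the same change on two cores in this assay, a 7.1-fold lower number (0.85 log units; beyond the scatter) from compound 1 to compound 2 and a 370-fold lower number (2.57 log units; beyond the scatter) from compound 3 to compound 4, 52-fold (1.72 log units) apart, beyond the scatter of two such steps. This rests on one pair of compounds per core, and the two cores differ in more than one place, so the compounds do not show which difference goes with the gap between the steps, nor what size the step would take on a third core.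

On these data alone, it remains open whether another group on the same aromatic carbon, such as chloro, an amine or a carboxylic acid, would follow bromo on either core. As far as these compounds go, it is also open whether the gap would persist on a core that differs from the core of compound 1 in a single place.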